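This account rests on a few compounds, and the source may have more. Where it says the series, first, only, none or still open, it means among the compounds named here.

Compound 2 `CC(C)CN(Cc1ccc(N2CCN(CS(C)(=O)=O)CC2)cc1)S(=O)(=O)Cc1ccccc1` stands at a limit: in a physicochemical assay for solubility, in phosphate buffer, measured as kinetic solubility, with a stated time of 24 h, at pH 7.4 (on this read-out higher numbers stand for higher solubility and lower numbers for lower solubility), compound 2 gives <= 1000 nM. Compound 1 `CC(C)CN(Cc1ccc(N2CCN(S(C)(=O)=O)CC2)cc1)S(=O)(=O)Cc1ccccc1` sits at the same limit, giving <= 1000 nM in this assay, which is the limit of <= 1000 nM in this assay, at which 2 of the 3 values shown sit. Compound 3 `CC(C)CN(Cc1ccc(N2CCC(O)CC2)cc1)S(=O)(=O)Cc1ccccc1` gives 7000 nM in this assay, so the steps of an at least 7.0-fold higher number from compound 1 to compound 3 (0.84 log units; beyond the scatter) and an at least 7.0-fold higher number from compound 2 to compound 3 (0.84 log units; beyond the scatter) are read from that limit upward, while a step that the two limits leave unreadable from compound 1 to compound 2 stays unreadable. Compound 4 `CC(C)CN(Cc1ccc(N2CCC(C(N)=O)CC2)cc1)S(=O)(=O)Cc1ccccc1` differs from compound 2 by 4-carbamoylpiperidin-1-yl in place of 4-((methylsulfonyl)methyl)piperazin-1-yl on an aromatic carbon. As in the step to compound 3, the piperazinyl group gives way to a 4-substituted piperidin-1-yl, and a rise in this assay of the order of an at least 7.0-fold higher number from compound 2 to compound 3 (0.84 log units; beyond the scatter) is therefore expected. Compound 4 is estimated at 5000 nM, between 1500 nM and 15000 nM, an expected step of an at least 5.0-fold higher number from compound 2 to compound 4 (0.69 log units; beyond the scatter).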

Compound 4, solubility: <= 1000 nM
Compound 4: only a limit was reported (the forecaster's own chance of this, stated with the estimate: 25%); middle value at least 5.0-fold (0.69 log units) away from the limit.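

Swapping the piperazinyl group for a 4-substituted piperidin-1-yl does not by itself lift the read-out in this assay, since the substituent on the saturated ring carbon matters: an at least 7.0-fold lower number from compound 3 to compound 4 (0.84 log units; beyond the scatter). Hydroxy in compound 3 therefore stands apart from carbamoyl in compound 4 at this position. The steps joining compound 4 to compound 1 and compound 2 cannot be read, and the result for compound 4 is a limit: the limit of <= 1000 nM in this assay, at which 3 of the 4 values shown sit.

On these data alone, how far compound 1, compound 2 and compound 4 lie under that limit remains open. So does whether an amine or a carboxylic acid on the piperidine ring would read like hydroxy or like carbamoyl.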